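Heptyl in place of tert-butyl on the shared core

The source may report more compounds than this note shows. Statements on the series, on what has been measured and on what is new or still open speak of the compounds shown alone.

Compound 1 `CC(C)c1ccccc1NC(=O)N[C@H](C)c1ccccc1` gives 17% in an ADME assay on the whole organism with Oryza sativa as the target, tested at 10 uM; on this read-out higher numbers stand for a weaker effect at the one concentration tested and lower numbers for a stronger effect. Compound 2 `C[C@@H](NC(=O)Nc1ccc(C(C)(C)C)cc1)c1ccccc1` gives 53%, and compound 3 `C[C@H](NC(=O)Nc1ccc(C(C)(C)C)cc1)c1ccccc1` gives 64% in this assay. Within the data shown here, the single measured step, a number 11 percentage points higher from compound 2 to compound 3 (beyond the scatter), goes with the fact that compounds 2 and 3 differ only in the configuration as drawn. Compound 3 stands highest of the three numbers, with compound 2 nearest and compound 1 furthest. Compound 4 `CCCCCCCc1ccc(NC(=O)N[C@@H](C)c2ccccc2)cc1` carries the change (heptyl in place of tert-butyl on an aromatic carbon). Among the measured compounds shown here, no measured step involves this change; the only step in hand is the configurational one between compound 2 and compound 3, and it offers no guide to a replacement of the aromatic substituent. The step of a number 4 percentage points lower from compound 3 to compound 4 (within the scatter) is therefore expected to stay within the scatter. Compound 4 is estimated at 60%, within 35% to 85%.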

Compound 4, a percentage reported as activity, at one concentration (the size of the read-out at that concentration, not a potency): 99%
For compound 4 the middle estimate is 39 percentage points below the measured one; measured number above the stated range.
By their numbers in this assay, from the lowest: compound 1; then compound 2; then compound 3; then compound 4.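

Heptyl in place of tert-butyl on an aromatic carbon, para to a large group, goes with a number 35 percentage points higher from compound 3 to compound 4 (beyond the scatter) in this assay. The substituent at this position therefore has a large bearing on the read-out, and here the change runs towards a weaker effect at the one concentration tested. Nothing in hand explains this step.

As far as these compounds go, it remains open whether the step follows chain length or the loss of branching, and a straight butyl chain at this carbon would separate the two. Also open, from the compounds shown here alone, is whether the opposite configuration of the heptyl compound would read differently.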